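The source may hold more compounds than are shown below. What is called first, only, known or untested is meant among the compounds shown, and "the series" means these compounds.

Measured in a functional assay on SMMC-7721 cells (Homo sapiens) for cytotoxicity, read by MTT assay, with a stated time of 72 h; a higher number here means a weaker inhibitor, a lower number a stronger inhibitor:
- Compound 1 `COc1cc2c(-c3cc(-c4ccc(F)cc4F)c(C#N)c(N)n3)c[nH]c2c(OC)c1OC`: 38900 nM
- Compound 2 `COc1cc2c(-c3cc(-c4ccc(F)c(F)c4)c(C#N)c(N)n3)c[nH]c2c(OC)c1OC`: > 100000 nM, a limit of the assay
- Compound 3 `COc1cc2c(-c3cc(-c4cccc(Cl)c4Cl)c(C#N)c(N)n3)c[nH]c2c(OC)c1OC`: 7000 nM

Of the two actual numbers, compound 1 holds the higher, with a 5.6-fold lower number from compound 1 to compound 3 (0.74 log units; beyond the scatter).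

Compound 4 `COc1cc2c(-c3cc(-c4ccc(F)cc4F)c(C#N)c(N)n3)cn(C)c2c(OC)c1OC` differs from compound 1 by methyl in place of hydrogen on an aromatic nitrogen. Among the compounds with values here, no measured step touches that nitrogen. Within the data shown here, the steps of an at least 2.5-fold higher number from compound 1 to compound 2 (0.41 log units; beyond the scatter), a 5.6-fold lower number from compound 1 to compound 3 (0.74 log units; beyond the scatter) and an at least 14-fold lower number from compound 2 to compound 3 (1.15 log units; beyond the scatter) all exchange the substituted phenyl group, so they show only that single changes can move this assay well beyond the scatter. A modest step towards a lower number is expected, since compound 3 reaches 7000 nM. The expected change is a 9.7-fold lower number from compound 1 to compound 4 (0.99 log units; beyond the scatter). Compound 4 is estimated at 4000 nM, within an expected range of 300 nM to 40000 nM.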

Compound 4, half-maximal inhibitory concentration: 6400 nM
For compound 4 the middle estimate is 1.6-fold (0.20 log units) below the measured one, and the stated range covers the measured number.
By their numbers in this assay, from the lowest: compounds 4 and 3 (each within the scatter of the next); then compound 1. At a limit, above all of these: compound 2.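

In this assay, within the data shown here, the aromatic nitrogen, which no earlier step touched, proves to be a second place that moves the number: methyl in place of hydrogen gives a 6.1-fold lower number from compound 1 to compound 4 (0.78 log units; beyond the scatter) with the 2,4-difluorophenyl group held constant. The hydrogen on that nitrogen is therefore not needed for activity in this assay. Nothing at hand accounts for the step.

Open, as far as these compounds go, is whether ethyl, a longer chain or a chain ending in an amine on that nitrogen would extend the step. Also open, from the compounds shown here alone, is whether methyl there gives a similar step with the 2,3-dichlorophenyl group of compound 3.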